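The source may hold more compounds than are shown below. What is called first, only, known or untested is meant among the compounds shown, and "the series" means these compounds.

Three compounds have numbers in an assay on microsomes from brain (strain Sprague-Dawley) for inhibition of Fatty-acid amide hydrolase 1 (Rattus norvegicus), read by fluorescence and HPLC, with stated times of 10 min and 60 min (on this read-out lower numbers stand for stronger inhibition and higher numbers for weaker inhibition), and compound 2 is the starting point for the present step. Compound 1, `O=C(NCCCCCCn1ccc2ccccc21)Oc1cccnc1`, gives 5.2 nM. Compound 3, `O=C(NCCCCCCn1ncc2ccccc21)Oc1ccccc1`, gives 920 nM. Compound 2, `CC(=O)c1c(-c2ccccc2)c(-c2ccccc2)n(CCCCCCNC(=O)Oc2ccccc2)c1C`, stands apart from these two: in this assay it gives only a limit, > 10000 nM, and not a number. Among the measured compounds shown here, that limit is the one described as the limit of > 10000 nM in this assay, at which 1 of the 3 values shown sits, so compound 2 is the single member of the set whose strength could not be put on the scale at all.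

Compound 4, `Cc1c(C#N)c(-c2ccccc2)c(-c2ccccc2)n1CCCCCCNC(=O)Oc1ccccc1`, differs from compound 2 in one place: cyano in place of acetyl on an aromatic carbon. For the measured compounds named here, no measured pair in the set carries a change of this kind, so there is no step to read the size from. Because compound 2 sits at the limit > 10000 nM, the expectation for compound 4 is that it too will show no strength beyond that limit, with no step beyond the scatter in either direction. Compound 4 is therefore estimated at 15000 nM, within a range from 3000 nM to 60000 nM. The step this estimate implies, a step that the limit leaves unreadable from compound 2 to compound 4, is expected to be no more than the scatter.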

Compound 4, half-maximal inhibitory concentration: 8700 nM
Estimate against measurement, compound 4: 1.7-fold (0.24 log units) above, and the stated range covers the measured number.
By their numbers in this assay, from the lowest: compound 1; then compound 3; then compound 4. At a limit, above all of these: compound 2.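

In this assay, cyano in place of acetyl on this aromatic carbon of the five-membered aromatic ring gives a pair in which compound 4 has a number on the scale, while compound 2 has only a limit. The change reads as an at least 1.1-fold lower number from compound 2 to compound 4 (0.06 log units; that floor lies within the scatter), so the pair fixes only a floor for its size, and the true step could be larger than that floor. Only this floor can be read from the pair because compound 2 has no number of its own: the limit of > 10000 nM in this assay, at which 1 of the 4 values shown sits.

The compounds shown leave open whether the number for compound 4 is tied to cyano itself, or whether another group on this aromatic carbon, such as a carboxylic acid, an amine or a methyl ester, would read the same in this assay. They also leave open what would follow, with cyano kept in place, if a hydrogen stood in place of the phenyl group on the ring atom next to this carbon, or an ethyl group in place of the methyl group on the other ring atom next to it.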